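The source may hold more compounds than are shown below. What is called first, only, known or untested is meant among the compounds shown, and "the series" means these compounds.

Measured in a functional assay on Jurkat cells (Homo sapiens) for inhibition, read by MTT assay, with a stated time of 72 h; on this read-out lower numbers stand for stronger inhibition and higher numbers for weaker inhibition:
Compound 1 `C=C(Br)C(=O)Nc1cccc(/C=C/C(=O)Nc2ccc(F)cc2)c1`: 6200 nM
Compound 2 `C=C(Br)C(=O)Nc1cccc(/C=C/C(=O)Nc2ccc(OC)cc2)c1`: 470 nM

Of these two compounds, compound 2 has the lower number, at 470 nM, and so shows the stronger inhibition in this assay. The next compound, compound 3 `C=C(Br)C(=O)Nc1cccc(/C=C/C(=O)Nc2ccc(SC(F)(F)F)cc2)c1`, keeps the shared core and changes one group: (trifluoromethyl)sulfanyl in place of methoxy on an aromatic carbon. In words, (trifluoromethyl)sulfanyl takes the place of methoxy on an aromatic carbon, para to a large group.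

Among the measured compounds shown here, only one measured step bears on this place: a 13-fold lower number from compound 1 to compound 2 (1.12 log units; beyond the scatter). This step, with methoxy in place of fluoro, is large and beyond the scatter. For the measured compounds named here, it shows that a change at this place can move the number strongly, but it rests on a single pair, and no measured compound carries (trifluoromethyl)sulfanyl. With compound 1 at 6200 nM, the one measured replacement for methoxy gives a much higher number, so a rise is expected here too, though probably a smaller one. The expected step is a 3.2-fold higher number from compound 2 to compound 3 (0.50 log units; beyond the scatter). The estimate for compound 3 is 1500 nM, with an expected range of 350 nM to 6500 nM.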

Compound 3, half-maximal inhibitory concentration: 30100 nM
Beside the measured number, compound 3's estimate is 20-fold (1.30 log units) below it, and the stated range ends below it.
By their numbers in this assay, from the lowest: compound 2; then compound 1; then compound 3.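

In this assay, (trifluoromethyl)sulfanyl in place of methoxy on the aromatic carbon para to a large group gives a 64-fold higher number from compound 2 to compound 3 (1.81 log units; beyond the scatter) and so adds a second large step at this place, which until now rested on a single pair. The same place also separates compound 3 from the fluoro compound, with a 4.9-fold higher number from compound 1 to compound 3 (0.69 log units; beyond the scatter) as a modest step, so the three groups now fall into a clear order: methoxy gives the lowest number, fluoro the next and (trifluoromethyl)sulfanyl the highest, and methoxy is the only one of the three to reach the low range seen for compound 2. Nothing measured here accounts for this order or for the wide gap between the two groups that carry a single atom bonded to the ring through oxygen or sulfur.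

The compounds shown leave open where other groups at this place would fall in this order, such as an amine, a hydroxyl or a longer alkoxy chain like ethoxy, and whether methylsulfanyl would stay close to methoxy or move toward compound 3. They also leave open whether the same order would hold with a change elsewhere on the shared core.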